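Compound 3: hydrogen in place of methyl

A few compounds are considered here, and "the series" means these few. Any claim that something is new, unique, unknown or untested is made for them only; others in the source may bear on it.

Measured in an ADME assay on HepG2 cells (Homo sapiens) for cytotoxicity; on this read-out lower numbers stand for higher toxicity in this test and higher numbers for lower toxicity in this test:
Compound 1 `CC(C)(C)CC#Cc1cc2ncnc(Nc3ccc(OCc4cccc(F)c4)c(Cl)c3)c2s1`: 29.3 uM
Compound 2 `CN1CCN(CC#Cc2cc3c(Nc4ccc(OCc5cccc(F)c5)c(Cl)c4)ncnc3s2)CC1`: 15 uM

Compound 2 stands with compound 1 on these numbers, since the two values lie within the usual scatter of each other and cannot be told apart. Compound 3 `Fc1cccc(COc2ccc(Nc3ncnc4sc(C#CCN5CCNCC5)cc34)cc2Cl)c1` has not yet been measured. It differs from compound 2 in one place: hydrogen in place of methyl on an amine nitrogen in a ring. This is hydrogen in place of methyl on an amine nitrogen in a ring, so 4-methylpiperazin-1-yl becomes piperazin-1-yl. For the measured compounds named here, no measured pair shows this change. The expectation therefore rests on compound 2 at 15 uM, and no step beyond the scatter is expected in this assay. The estimated step of a 1.1-fold lower number from compound 2 to compound 3 (0.03 log units; within the scatter) is expected to stay within the scatter. For compound 3 the estimated value is 14 uM, with an expected range from 6 uM to 32 uM.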

Compound 3, half-maximal toxic concentration: 7.7 uM
Compound 3: middle estimate off by 1.8-fold (0.26 log units), on the high side, within the range that was stated.
By their numbers in this assay, from the lowest: compounds 3, 2 and 1 (each within the scatter of the next, the first and the last beyond it).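

In this assay, for the compounds shown here, this pair gives the first reading of a single change at this position: hydrogen in place of methyl on an amine nitrogen in a ring, turning 4-methylpiperazin-1-yl into piperazin-1-yl, comes with a 1.9-fold lower number from compound 2 to compound 3 (0.29 log units; within the scatter). Since this step lies within the scatter, compound 2 and compound 3 cannot be told apart on this read-out. The methyl on this ring nitrogen is therefore not shown to matter in this test.

Going by these compounds, it remains open whether an ethyl or acetyl group on the same nitrogen would give a step beyond the scatter. On these data alone, it is equally open whether a morpholine ring in place of the piperazine would do so. No measurement at hand offers an explanation for this result.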